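The source may report more compounds than this note shows. Statements on the series, on what has been measured and on what is new or still open speak of the compounds shown alone.

Compound 1, `O=C(O)[C@H](CO)NC(=O)[C@H]1C[C@H](O)CN1`, in a physicochemical assay for metabolic stability, read by HPLC, with a stated time of 12 h, at pH 1.2 (a lower number here means that the compound disappears faster, a higher number that the compound lasts longer), gives > 12 h. Compound 2, `O=C(O)[C@H](CO)NC(=O)[C@@H]1C[C@H](O)CN1`, in this assay gives > 12 h.

Compound 1 stands at the upper limit of this assay: its value is a limit of the assay, not a number, so all that is known is that it lasts at least as long as the assay was run. For the measured compounds named here, the only measured step, a step that the two limits leave unreadable from compound 1 to compound 2, cannot be read, because of the limit of > 12 h in this assay, at which 2 of the 2 values shown sit. Those two compounds differ only in configuration at a ring carbon, as the fact that compounds 1 and 2 differ only in the configuration as drawn states, and that change left both beyond the limit.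

Compound 3, `O=C(O)[C@@H](CO)NC(=O)[C@H]1C[C@H](O)CN1`, differs from compound 1 as follows: the two compounds have the same atoms and bonds and differ only in configuration as drawn: 1 of 3 stereo elements differ; a stereocentre at a saturated chain carbon is drawn S in compound 1 and R in compound 3. Going by the values given here, no measured step bears directly on this chain stereocentre. Among the compounds with values here, the one step that is known, between the two ring diastereomers, shows no readable change, and that is the only guide. The step expected here is a number no higher from compound 1 to compound 3 (the limit leaves the size open), which is none beyond the scatter. Compound 3 is therefore expected to give about 12 h, in the range 6 h to 12 h, most likely again reported only as a limit.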

Compound 3, half-life: > 12 h
Compound 3: no number, only a limit; the forecaster's own chance of this, stated with the estimate: 85%; the middle value sits exactly at the limit.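

The steps among compound 1, compound 2 and compound 3 cannot be read, because all three values are the same limit of the assay, not numbers: the limit of > 12 h in this assay, at which 3 of the 3 values shown sit. The compounds shown leave open how long each one actually lasts, and whether changing the configuration at either stereocentre alters that at all.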